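Adding a methoxy group to the core of compound 2

The source may report more compounds than this note shows. Statements on the series, on what has been measured and on what is new or still open speak of the compounds shown alone.

Of the compounds shown here, three sharing one core have been measured in an assay on HEK293 cells for displacement of a labelled ligand from 5-hydroxytryptamine receptor 6 (Homo sapiens); a higher number here means a weaker inhibitor, a lower number a stronger inhibitor. Compound 1, `O=S(=O)(c1c(Cl)cccc1Cl)N1CCOc2c(N3CCNCC3)cccc21`, gives 0.0631 nM. Compound 2, `O=S(=O)(c1ccccc1)N1CCOc2c(N3CCNCC3)cccc21`, gives 12.6 nM, and compound 3, `O=S(=O)(c1cccc(F)c1)N1CCOc2c(N3CCNCC3)cccc21`, gives 10 nM. Among these, compound 2 has the highest number: compound 3 sits close, since the difference a 1.3-fold lower number from compound 2 to compound 3 (0.10 log units; within the scatter) lies within the scatter, while compound 1 is far away, as shown by a 200-fold higher number from compound 1 to compound 2 (2.30 log units; beyond the scatter).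

Compound 4, `COc1cc(N2CCNCC2)c2c(c1)N(S(=O)(=O)c1ccccc1)CCO2`, differs from compound 2 in one place: methoxy in place of hydrogen on an aromatic carbon. For the measured compounds named here, no measured step touches this part of the core; the two large steps of a 200-fold higher number from compound 1 to compound 2 (2.30 log units; beyond the scatter) and a 160-fold higher number from compound 1 to compound 3 (2.20 log units; beyond the scatter) concern the group on the sulfonyl sulfur, and the only small aromatic substitution seen, a 1.3-fold lower number from compound 2 to compound 3 (0.10 log units; within the scatter), also sits on that group and stays within the scatter. Going by the values given here, with no direct precedent, a modest change is the most reasonable expectation, so the step is expected to stay within or near the scatter in this assay .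

For compound 4 the expected value in this assay is 12 nM, with a range from 4 nM to 40 nM. This estimate corresponds to an expected step of a 1.1-fold lower number from compound 2 to compound 4 (0.02 log units; within the scatter).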

Compound 4, inhibition constant: 0.398 nM
The estimate for compound 4 lay 30-fold (1.48 log units) above the measured number; measured number outside the range, below it.
By their numbers in this assay, from the lowest: compound 1; then compound 4; then compounds 3 and 2 (each within the scatter of the next).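

In this assay the core of compound 2 proves to be a sensitive place: placing a methoxy group on the aromatic carbon meta to a piperazin-1-yl group gives a 32-fold lower number from compound 2 to compound 4 (1.50 log units; beyond the scatter) and does so with only 2 heavy atoms added. Until now, a large step had been seen only on changing the group on the sulfonyl sulfur, as in a 200-fold higher number from compound 1 to compound 2 (2.30 log units; beyond the scatter) and the one fluoro substitution shown, a 1.3-fold lower number from compound 2 to compound 3 (0.10 log units; within the scatter) on that same group, stayed within the scatter, so the number in this assay can also move strongly through a change on the core. Nothing available here accounts for why this single substitution has so large an effect.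

The compounds shown leave open whether this step belongs to methoxy itself or whether a fluoro, a hydroxy, an ethoxy or an amine on the same carbon would give a similar one. They also leave open whether methoxy at this carbon would lower the number as much if the sulfonyl sulfur carried 2,6-dichlorophenyl in place of phenyl.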